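The compounds below may be only part of what the source reports. "The series", "measured", "known", "first", "only" and "open" are said of these compounds alone.

The measured compounds, each in a functional assay on DU-145 cells (Homo sapiens) for cytotoxicity, read by MTT assay, with a stated time of 24 h; a higher number here means a weaker inhibitor, a lower number a stronger inhibitor:
Compound 1 `CCCCCCCC/C=C\CCCCCCCC(=O)Nc1nnc(S[C@@H]2O[C@H](COC(C)=O)[C@H](OC(C)=O)[C@H](OC(C)=O)[C@H]2OC(C)=O)s1` gives 42000 nM.
Compound 2 `CCCCCCCC(=O)Nc1nnc(S[C@@H]2O[C@H](CO)[C@H](O)[C@H](O)[C@H]2O)s1` gives "not active" (no number reported).
Compound 3 `CCCCCCCCCC(=O)Nc1nnc(S[C@@H]2O[C@H](COC(C)=O)[C@H](OC(C)=O)[C@H](OC(C)=O)[C@H]2OC(C)=O)s1` gives 34400 nM.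

Compound 2 stands apart from the other two: for it no number was reported, only that it was not active, so it cannot be placed against compound 1 or compound 3 on a numerical scale. Compound 4 `CCCCCC(=O)Nc1nnc(S[C@@H]2O[C@H](CO)[C@H](O)[C@H](O)[C@H]2O)s1` differs from compound 2 in a single place: hydrogen in place of ethyl on a saturated chain carbon, five bonds along the chain from a carbonyl carbon.

For the measured compounds named here, only one measured step bears on a change of chain length: a 1.2-fold lower number from compound 1 to compound 3 (0.09 log units; within the scatter). That step, made on the acetylated form of the shared core, was within the scatter, so shortening or lengthening the chain there made no measurable difference. Compound 2 itself, on the free-hydroxyl form of the core, gave no number at all. Nothing in these data suggests that a shorter chain would turn an inactive compound into an active one, so compound 4 is expected to show little or no measurable activity, and most likely only a limit would again be reported. If a number is obtained, compound 4 is estimated at 90000 nM, with a range from 30000 nM to 300000 nM.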

Compound 4, half-maximal inhibitory concentration: "not active" (no number reported)
No number was reported for compound 4, so the estimate cannot be set against anything.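

Compound 2 and compound 4 are both reported as not active in this assay, with no number for either, so no step can be read between them. The compounds shown leave open whether any chain length on the free-hydroxyl form of the core gives a measurable value. No evidence here bears on this result.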